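The source may hold more compounds than are shown below. What is called first, only, known or untested is meant among the compounds shown, and "the series" means these compounds.

Measured so far:
compound 1, `CN(C[C@H]1Cc2c(cccc2N2C[C@@H]3C[C@H]2CN3)CN1)[C@H]1CCCc2cccnc21`: 100%
compound 2, `c1cnc2c(c1)CCC[C@@H]2N(CC1CCCCC1)C[C@H]1Cc2c(cccc2N2CCNCC2)CN1`: 81.6%

In an ADME assay on microsomes from liver (Homo sapiens) for metabolic stability, read by LC-MS, with a stated time of 10 min (on this read-out lower numbers stand for a less stable compound and higher numbers for a more stable compound), compound 1 gives 100%, the highest of the two numbers recorded. Its nearest neighbour is compound 2, which in this assay gives 81.6%, a number beyond the usual scatter below that of compound 1. Among the measured compounds shown here, the two differ in more than one place, so no single step is drawn between them.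

Compound 3, `C[C@@H]1CN(c2cccc3c2C[C@H](CN(C)[C@H]2CCCc4cccnc42)NC3)C[C@H](C)N1C`, has not yet been measured. It differs from compound 1 in one place: a group of 9 heavy atoms (7 carbon, 2 nitrogen; one six-membered non-aromatic ring with 2 hetero atoms) in place of a group of 7 heavy atoms (5 carbon, 2 nitrogen; 2 five-membered non-aromatic rings with 1 hetero atom each), on an aromatic carbon. Compound 1 already sits at the top of the scale, so the step can only be flat or downward. Nothing measured here shows how this particular change behaves, so the expectation rests on compound 1 alone. A modest fall, possibly beyond the scatter, is expected, giving a step of a number 22 percentage points lower from compound 1 to compound 3 (beyond the scatter) in this assay. Compound 3 is therefore estimated at 78%, within a range from 50% to 100%.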

Compound 3, percent of the compound remaining: 24.6%
For compound 3 the middle estimate is 53.4 percentage points above the measured one; the whole stated range lies above it.
By their numbers in this assay, from the lowest: compound 3; then compound 2; then compound 1.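

On an aromatic carbon of the shared core, putting 3,4,5-trimethylpiperazin-1-yl in place of the group with two five-membered non-aromatic rings gives a number 75.4 percentage points lower from compound 1 to compound 3 (beyond the scatter) in this assay. Among the compounds shown here, the earlier pair differed in more than one place, so this is the first single change that can be read, and it shows that the group on this carbon can matter greatly for this read-out. The two groups differ at once in ring system, size and hydrogen-bond donors, and nothing at hand separates these differences or explains the fall.

On these data alone, it remains open how a morpholine on this carbon, with the rest of compound 1 unchanged, would stand in this assay. A piperazine without the three methyl groups could also fall nearer to either compound 1 or compound 3.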